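Removing a Nitro Group: Expected Effect on Paw Edema Inhibition

The source may report more compounds than this note shows. Statements on the series, on what has been measured and on what is new or still open speak of the compounds shown alone.

Measured compounds:
compound 1 `N#CC1=C(NCC(=O)N2CCOCC2)N(c2ccccc2)C(=O)N2CCCCC(N3CCCC3)C12` gives 73.5%
compound 2 `N#CC1=C(NCC(=O)O)N(c2ccccc2)C(=O)N2CCCCC(N3CCCC3)C12` gives 89.2%
compound 3 `N#CC1=C(/N=C/Nc2ccc([N+](=O)[O-])cc2)N(c2ccccc2)C(=O)N2CCCCC(N3CCCC3)C12` gives 85.6%

These numbers come from a functional assay on the whole organism (strain albino) for inhibition, with Rattus norvegicus as the target, read by paw edema, with stated times of 1 h and 3 h, at a dose of 20 mmol/kg by the intraperitoneal route; a higher number here means a stronger effect of the compound at the dose given, a lower number a weaker effect. Compound 3 stands second highest of the three, with compound 2 nearest, a gap that is within the scatter, and compound 1 furthest, a gap beyond the scatter. Compound 4 `N#CC1=C(/N=C/Nc2ccccc2)N(c2ccccc2)C(=O)N2CCCCC(N3CCCC3)C12` differs from compound 3 only at the outer ring: hydrogen in place of nitro on an aromatic carbon. For the measured compounds named here, none of the measured steps touches this ring; the steps of a number 15.7 percentage points higher from compound 1 to compound 2 (beyond the scatter) and a number 12.1 percentage points higher from compound 1 to compound 3 (beyond the scatter) change a different part of the molecule, and the step of a number 3.6 percentage points lower from compound 2 to compound 3 (within the scatter) lies within the scatter. So nothing points to a step beyond the scatter. Compound 4 is expected to give 82% (range 65% to 95%), a step of a number 3.6 percentage points lower from compound 3 to compound 4 (within the scatter).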

Compound 4, a percentage reported as inhibition, in the whole organism at one dose (the size of the read-out at that dose, not a potency): 79.3%
Estimate against measurement, compound 4: 2.7 percentage points above, within the range that was stated.
By their numbers in this assay, from the lowest: compounds 1, 4, 3 and 2 (each within the scatter of the next, the first and the last beyond it).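

In this assay, hydrogen in place of nitro gives a number 6.3 percentage points lower from compound 3 to compound 4 (within the scatter) on this aromatic carbon, so the nitro group is not shown to be needed for the effect at this dose. With a number 9.9 percentage points lower from compound 2 to compound 4 (within the scatter) and a number 5.8 percentage points higher from compound 1 to compound 4 (within the scatter) the anilino group cannot be separated from the side chains of the other two compounds. Nothing available explains these small steps.

From the compounds shown here alone, whether an amine, a methoxy group or a chlorine atom on this same carbon would give a step beyond the scatter stays open. A read-out at one dose also leaves the potency of these compounds open.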